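Configuration and potency in a pair of naphthyl esters

The compounds below may be only part of what the source reports. "The series", "measured", "known", "first", "only" and "open" are said of these compounds alone.

- Compound 1 `COC(=O)[C@@H]1CN(C)CC[C@@H]1c1ccc2ccccc2c1`: 8.2 nM
- Compound 2 `COC(=O)[C@H]1CN(C)CC[C@@H]1c1ccc2ccccc2c1`: 46 nM

In a functional assay (brain) with Rattus norvegicus as the target (on this read-out lower numbers stand for stronger inhibition and higher numbers for weaker inhibition), compound 2 gives 46 nM, the higher of the two numbers, and it stands apart from compound 1 beyond the scatter. Compound 3 `COC(=O)[C@H]1CN(C)CC[C@H]1c1ccc2ccccc2c1` has not yet been measured. It is reached from compound 2 by one change: the two compounds have the same atoms and bonds and differ only in configuration as drawn: 1 of 2 stereo elements differ; a stereocentre at a saturated ring carbon is drawn S in compound 2 and R in compound 3. Among the measured compounds shown here, only one measured step bears on this, a 5.6-fold higher number from compound 1 to compound 2 (0.75 log units; beyond the scatter), and it also changes configuration alone: the fact that compounds 1 and 2 differ only in the configuration as drawn. That step concerned the other stereocentre, so it is only a loose guide to size and says nothing certain about direction. A change of similar modest size is expected, leaning towards weaker inhibition, and the expected step is a 2.6-fold higher number from compound 2 to compound 3 (0.42 log units; beyond the scatter). In this assay compound 3 is estimated at 120 nM, within an expected range of 25 nM to 600 nM.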

Compound 3, half-maximal inhibitory concentration: 13 nM
Beside the measured number, compound 3's estimate is 9.2-fold (0.97 log units) above it; the whole stated range lies above it.
By their numbers in this assay, from the lowest: compounds 1 and 3 (each within the scatter of the next); then compound 2.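

At the stereocentre changed here, inversion gives a 3.5-fold lower number from compound 2 to compound 3 (0.55 log units; beyond the scatter) in this assay, so this centre also moves the number beyond the scatter, this time towards stronger inhibition. For the mirror-image pair the same read-out gives a 1.6-fold higher number from compound 1 to compound 3 (0.20 log units; within the scatter), so inverting both stereocentres leaves no separation that can be read, and among these three only compound 2 stands apart. With no atom or bond changing, the gap between compound 2 and compound 3 rests on the arrangement of the stereocentres alone: the fact that compounds 2 and 3 differ only in the configuration as drawn

On these data alone, it remains open whether the mirror image of compound 2 would stand apart in the same way. Also open, as far as these compounds go, is whether this pattern would hold if a carboxylic acid or an amide replaced the methyl ester, or a phenyl group replaced the naphthyl group.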